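The source may hold more compounds than are shown below. What is called first, only, known or untested is meant among the compounds shown, and "the series" means these compounds.

Measured so far:
compound 1 `OCc1cn(Cc2ccccc2)c2ccccc12` — 112 nM
compound 2 `OCc1cn(Cc2cccc(F)c2)c2ccccc12` — 40 nM
compound 3 `OCc1cn(Cc2cccc(Br)c2)c2ccccc12` — 28 nM

In a functional assay on NCI-H460 cells (Homo sapiens) for cytotoxicity, read by sulforhodamine B assay, with a stated time of 3 days (a higher number here means a weaker inhibitor, a lower number a stronger inhibitor), compound 1 has the highest number of the three. The steps of a 2.8-fold lower number from compound 1 to compound 2 (0.45 log units; beyond the scatter) and a 4.0-fold lower number from compound 1 to compound 3 (0.60 log units; beyond the scatter) both run from compound 1 to a lower number, while a 1.4-fold lower number from compound 2 to compound 3 (0.15 log units; within the scatter) is within the scatter.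

Compound 4 `O=[N+]([O-])c1ccc(Cn2cc(CO)c3ccccc32)cc1` differs from compound 1 by nitro in place of hydrogen on an aromatic carbon. The two measured steps each place a halogen on an aromatic carbon of the same ring; the nitro group is a different substituent, so they bear on compound 4 only loosely. A modest drop of similar size is nonetheless expected, a 2.2-fold lower number from compound 1 to compound 4 (0.35 log units; beyond the scatter), with a wide margin of doubt. Compound 4 is therefore estimated at 50 nM in this assay, between 18 nM and 160 nM.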

Compound 4, half-maximal inhibitory concentration: 79 nM
Estimate against measurement, compound 4: 1.6-fold (0.20 log units) below; the range from low to high includes it.
By their numbers in this assay, from the lowest: compounds 3, 2, 4 and 1 (each within the scatter of the next, the first and the last beyond it).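

In this assay nitro on an aromatic carbon, para to a large group, gives a 1.4-fold lower number from compound 1 to compound 4 (0.15 log units; within the scatter) and so, unlike the fluoro and bromo replacements, stays within the scatter. A substituent of three heavy atoms is therefore accepted at this place with no measurable change from compound 1. No measured property accompanies this result to account for it.

Open, as far as these compounds go, is whether the ring carbon or the group itself sets the size of these steps. Bromo or an amine para to a large group would help separate the two.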